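A Five-Membered Ring Swap on the Shared Core

This account rests on a few compounds, and the source may have more. Where it says the series, first, only, none or still open, it means among the compounds named here.

Of the compounds shown here, three built on one shared core have been measured in an assay on CHO-K1 cells for binding affinity to 5-hydroxytryptamine receptor 1B (Homo sapiens); on this read-out lower numbers stand for stronger inhibition and higher numbers for weaker inhibition. Compound 1 `CN(C)[C@H]1C[C@H](c2c[nH]c3ccc(C(=O)NCc4ccccc4)cc32)C1` gives 316 nM. Compound 2 `Cc1nc(Cc2ccc3[nH]cc([C@H]4C[C@H](N(C)C)C4)c3c2)n[nH]1` gives 3890 nM, which places it at the weak end of the set, well apart from compound 1 and beyond the usual scatter of that comparison. Compound 3 `CN(C)[C@H]1C[C@H](c2c[nH]c3ccc(CN4C(=O)NC(C)(C)C4=O)cc32)C1` gives 3800 nM, and the gap between compound 2 and compound 3 lies within the scatter, so the two cannot be told apart.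

Compound 4 `CN(C)[C@H]1C[C@H](c2c[nH]c3ccc(CN4C(=O)CNC4=O)cc32)C1` has not yet been measured. It differs from compound 2 in one place: 2,5-dioxoimidazolidin-1-yl in place of 5-methyl-1H-1,2,4-triazol-3-yl on a saturated chain carbon bound to an aromatic carbon. Going by the values given here, no measured pair shows this exact exchange. The nearest guide is compound 3, which gives 3800 nM and sits level with compound 2. The step from compound 2 to compound 4 in this assay is therefore expected to be a 1.1-fold lower number from compound 2 to compound 4 (0.05 log units; within the scatter), with no direction that stands out beyond the scatter. For compound 4 the estimated value in this assay is 3500 nM, with a likely range from 1400 nM to 9000 nM.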

Compound 4, half-maximal inhibitory concentration: 6310 nM
Compound 4: the middle estimate sits 1.8-fold (0.26 log units) below what was measured, and the stated range covers the measured number.
By their numbers in this assay, from the lowest: compound 1; then compounds 3, 2 and 4 (each within the scatter of the next).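

In this assay, going by these compounds alone, replacing the 5-methyl-1H-1,2,4-triazol-3-yl with 2,5-dioxoimidazolidin-1-yl on a saturated chain carbon bound to an aromatic carbon gives a 1.6-fold higher number from compound 2 to compound 4 (0.21 log units; within the scatter) and is the first direct one-place comparison in this set. At this place, then, a five-membered aromatic ring with 3 hetero atoms and a five-membered non-aromatic ring with 2 hetero atoms cannot be told apart on this read-out, even though the new ring brings 2 double bonds outside aromatic rings. Nothing measured here speaks to the reason for this result.

As far as these compounds go, whether an amine or a carboxylic acid in the same place would move the number beyond the scatter remains open. So does the question of whether a longer chain carrying the 2,5-dioxoimidazolidin-1-yl ring would read differently from compound 4.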